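This account rests on a few compounds, and the source may have more. Where it says the series, first, only, none or still open, it means among the compounds named here.

Measured in an ADME assay on MT4 cells (Homo sapiens) for cytotoxicity, read by MTT assay, with a stated time of 5 days; a higher number here means that more compound is tolerated, a lower number that less compound is tolerated:
- Compound 1 `CCCNc1cc(Oc2c(OC)cc3cc(C#N)ccc3c2OC)nc(Nc2ccc(C#N)cc2)n1`: > 125000 nM (a limit)
- Compound 2 `COc1cc2cc(C#N)ccc2c(OC)c1Oc1cc(NC2CCCCC2)nc(Nc2ccc(C#N)cc2)n1`: > 125000 nM (a limit)

Compound 2 has no exact number, only a limit: the limit of > 125000 nM in this assay, at which 2 of the 2 values shown sit. Compound 3 `COc1cc2cc(C#N)ccc2c(OC)c1Oc1cc(NCCCO)nc(Nc2ccc(C#N)cc2)n1` carries 3-hydroxypropyl in place of cyclohexyl on a nitrogen on an aromatic ring. Among the measured compounds shown here, the only measured step that bears on this is a step that the two limits leave unreadable from compound 1 to compound 2, so it offers no size to build on. Compound 2 sits at the limit of > 125000 nM, so no clear change is expected in this assay, though a modest drop remains possible. The expected change is an at least 1.1-fold lower number from compound 2 to compound 3 (0.05 log units; that floor lies within the scatter). Compound 3 is expected at 110000 nM, with an estimated range of 40000 nM to 125000 nM.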

Compound 3, half-maximal cytotoxic concentration: 23500 nM
Estimate against measurement, compound 3: 4.7-fold (0.67 log units) above; the measured number lies below the stated range.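

On this nitrogen, the earlier swap of one carbon group for another gave no readable change, but in this assay the group now proves able to shift the number: 3-hydroxypropyl in place of cyclohexyl gives an at least 5.3-fold lower number from compound 2 to compound 3 (0.72 log units; beyond the scatter). Hydroxy in place of hydrogen on the propyl chain, a single added atom, gives an at least 5.3-fold lower number from compound 1 to compound 3 (0.72 log units; beyond the scatter), so the ring need not be lost for this shift to appear. Both sizes are only floors because compound 1 and compound 2 rest on a limit: the limit of > 125000 nM in this assay, at which 2 of the 3 values shown sit.

Going by these compounds, whether an amine or a carboxylic acid in place of the hydroxy would move the number similarly remains open. So does the effect of a longer chain carrying the hydroxy.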